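A few compounds are considered here, and "the series" means these few. Any claim that something is new, unique, unknown or untested is made for them only; others in the source may bear on it.

Within the data shown here, in a functional assay on HeLa cells (Homo sapiens) for antiproliferative activity, with a stated time of 5 days (on this read-out higher numbers stand for weaker inhibition and lower numbers for stronger inhibition), compound 1 `CC1OC2(C=CC(=O)C=C2)N(c2nc(-c3ccc4ccccc4c3)nn2-c2ccc3ccccc3c2)C1=O` gives 300 nM, the higher of the two numbers so far. Compound 2 `O=C1C=CC2(C=C1)OCC(=O)N2c1nc(-c2ccc3ncccc3c2)nn1-c1ccccc1` gives 110 nM, and the gap between the two numbers lies beyond the scatter. Compound 3 `COc1ccc(-n2nc(-c3ccc4ccccc4c3)nc2N2C(=O)C(C)OC23C=CC(=O)C=C3)cc1` keeps the core of compound 1 but carries 4-methoxyphenyl in place of naphthalen-2-yl on an aromatic nitrogen. Among the measured compounds shown here, no measured pair shows this change alone, and compound 2 at 110 nM differs from compound 1 in several places, so it offers only a weak hint towards stronger inhibition. The expected step is a 1.5-fold lower number from compound 1 to compound 3 (0.18 log units; within the scatter), slightly towards stronger inhibition and not beyond the scatter. For compound 3 the estimate is 200 nM, with an expected range of 70 nM to 550 nM.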

Compound 3, half-maximal inhibitory concentration: 140 nM
For compound 3 the middle estimate is 1.4-fold (0.15 log units) above the measured one, within the range that was stated.
By their numbers in this assay, from the lowest: compounds 2 and 3 (each within the scatter of the next); then compound 1.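

In this assay, among these compounds, putting 4-methoxyphenyl in place of naphthalen-2-yl on an aromatic nitrogen gives a 2.1-fold lower number from compound 1 to compound 3 (0.33 log units; beyond the scatter) and is the first change here that can be read alone. This position therefore does not need the two-ring group: one aromatic ring carrying a methoxy group does modestly better. Nothing on hand gives a reason for this step. From the compounds shown here alone, how a plain phenyl or a 4-aminophenyl group would fare at this position remains open. So does whether the step would hold if the other naphthalen-2-yl group were replaced.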